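The source may hold more compounds than are shown below. What is called first, only, known or untested is meant among the compounds shown, and "the series" means these compounds.

Among the measured compounds shown here, in a functional assay on HL-60 cells (Homo sapiens) for cytotoxicity, read by luminescence and CellTiter-Glo, with a stated time of 3 days (on this read-out lower numbers stand for stronger inhibition and higher numbers for weaker inhibition), three related compounds have numbers so far. Compound 1 `N#Cc1ccc(NC(=O)c2cc(Cl)ccc2O)c(Cl)c1` gives 500 nM, compound 2 `N#Cc1ccc(NC(=O)c2cc(-c3ccncc3)ccc2O)cc1` gives 5410 nM, and compound 3 `O=C(Nc1ccc(C(F)(F)F)cc1)c1cc(Cl)ccc1O` gives 510 nM. Compound 3 therefore stands level with compound 1, within the scatter, and well below compound 2, beyond the scatter. Compound 4 `N#Cc1ccc(NC(=O)c2cc(Cl)ccc2O)cc1` has cyano in place of trifluoromethyl on an aromatic carbon, para to a large group (cyano in place of trifluoromethyl on an aromatic carbon). Although it differs elsewhere from compound 4, compound 1 also carries cyano and shows 500 nM, so no large loss is expected in this assay. The expected step is a 1.5-fold higher number from compound 3 to compound 4 (0.17 log units; within the scatter), a small one toward weaker inhibition. For compound 4 the estimated value is 750 nM, with an expected range of 280 nM to 2000 nM.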

Compound 4, half-maximal inhibitory concentration: 700 nM
Estimate against measurement, compound 4: 1.1-fold (0.03 log units) above; measured number inside the range.
By their numbers in this assay, from the lowest: compounds 1, 3 and 4 (each within the scatter of the next); then compound 2.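

In this assay, cyano in place of trifluoromethyl on this aromatic carbon, para to a large group, leaves the two compounds within the scatter (a 1.4-fold higher number from compound 3 to compound 4 (0.14 log units; within the scatter)), and hydrogen in place of chloro on an aromatic carbon does the same (a 1.4-fold higher number from compound 1 to compound 4 (0.15 log units; within the scatter)). Among the compounds shown here, the one step beyond the scatter is chloro in place of pyridin-4-yl (a 7.7-fold lower number from compound 2 to compound 4 (0.89 log units; beyond the scatter)), a modest one. No measured property bears on these results. From the compounds shown here alone, whether an amine or a carboxylic acid on the cyano carbon would keep the number level stays open, as does where a methoxy group in place of chloro would fall.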